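The source may report more compounds than this note shows. Statements on the series, on what has been measured and on what is new or still open speak of the compounds shown alone.

Compound 1 `CCCOc1cccc2ccc(N)nc12`: 1100 nM in an assay on cells with melanin-concentrating hormone receptor 1 (Homo sapiens) as the target, read by radioligand binding; on this read-out lower numbers stand for stronger inhibition and higher numbers for weaker inhibition.
Compound 2 `CC(CC(C)(C)C)Oc1cccc2ccc(N3CCCCC3)nc12`: > 2000 nM in this assay, which is a limit of the assay and not a number.

Compound 2 therefore stands at the edge of what this assay reports; the limit of > 2000 nM in this assay, at which 1 of the 2 values shown sits, is where one of the two values shown sits. Among the measured compounds shown here, compound 1 has a number and compound 2 only a limit, so no step between the two can be stated. Compound 3 `CC(CC(C)(C)C)Oc1cccc2cccnc12` follows from compound 2 by hydrogen in place of piperidin-1-yl on an aromatic carbon of the core of compound 2. With compound 2 known only as a limit, the step to compound 3 has no firm starting point. The expected step that the limit leaves unreadable from compound 2 to compound 3 in this assay is judged to be none beyond the scatter, with another limit the most likely outcome. Compound 3 is accordingly estimated at 4000 nM, within 1500 nM to 15000 nM.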

Compound 3, half-maximal inhibitory concentration: > 2000 nM
Compound 3: only a limit was reported; the forecaster's own chance of this, stated with the estimate: 75%; the middle value does not contradict the limit.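

Compound 2 and compound 3 are both reported in this assay only as limits of the assay, so no step can be read between them. The compounds shown leave open what hydrogen in place of piperidin-1-yl on an aromatic carbon does to the inhibition.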